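The compounds below may be only part of what the source reports. "The series", "measured", "known", "first", "only" and "open" are said of these compounds alone.

Compound 1 `CCNc1cc(-c2ccc(NC(=O)Nc3ccc(C)cc3)cc2C(F)(F)F)ccn1` gives 42.6% in an assay on isolated protein for inhibition of serine/threonine-protein kinase PLK1 (Homo sapiens), read by radiometric assay and 33P incorporation, with a stated time of 40 min, tested at 20 uM, in the presence of a further agent that is not named here; on this read-out higher numbers stand for more inhibition at the one concentration tested (going by the name of the read-out) and lower numbers for less inhibition.
Compound 2 `CCNc1cc(-c2ccc(NC(=O)Nc3cccc(Cl)c3)cc2C(F)(F)F)ccn1` gives 94.9% in this assay.
Compound 3 `CCNc1cc(-c2ccc(NC(=O)Nc3cccc4ccccc34)cc2C(F)(F)F)ccn1` gives 54.1% in this assay.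

Compound 3 stands second highest of the three: above compound 1 by a number 11.5 percentage points higher from compound 1 to compound 3 (beyond the scatter), yet far below compound 2 by a number 40.8 percentage points lower from compound 2 to compound 3 (beyond the scatter). Compound 4 `CCNc1cc(-c2ccc(NC(=O)Nc3ccccc3Cl)cc2C(F)(F)F)ccn1` is not yet measured; it differs from compound 3 by 2-chlorophenyl in place of naphthalen-1-yl on an amide-type nitrogen, on an amide-type nitrogen. Among the compounds with values here, two steps bear on this: a number 40.8 percentage points lower from compound 2 to compound 3 (beyond the scatter) shows a chlorophenyl group clearly ahead of naphthalen-1-yl, and a number 52.3 percentage points higher from compound 1 to compound 2 (beyond the scatter) shows the same chlorophenyl group far ahead of 4-methylphenyl. Within the data shown here, no measured compound carries 2-chlorophenyl, so whether it matches the 3-chlorophenyl of compound 2 remains open. Due to a number 40.8 percentage points lower from compound 2 to compound 3 (beyond the scatter), compound 4 is expected to show a number 17.9 percentage points higher from compound 3 to compound 4 (beyond the scatter). Compound 4 is estimated at 72%, with a range from 40% to 96%.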

Compound 4, a percentage reported as inhibition, at one concentration (the size of the read-out at that concentration, not a potency): 71.6%
Beside the measured number, compound 4's estimate is 0.4 percentage points above it; the measured number falls inside the stated range.
By their numbers in this assay, from the lowest: compound 1; then compound 3; then compound 4; then compound 2.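

Moving the chlorine around the ring on the amide-type nitrogen matters: a number 23.3 percentage points lower from compound 2 to compound 4 (beyond the scatter) comes with 2-chlorophenyl in place of 3-chlorophenyl, so the same atoms do not give the same inhibition. 2-Chlorophenyl still reads above the other two groups, with a number 29 percentage points higher from compound 1 to compound 4 (beyond the scatter) against 4-methylphenyl and a number 17.5 percentage points higher from compound 3 to compound 4 (beyond the scatter) against naphthalen-1-yl. Nothing measured here explains these differences.

Still open, going by these compounds, is how 4-chlorophenyl, or a phenyl ring carrying an amine or a carboxylic acid, would read at this nitrogen. Also open, on these data alone, is whether this order would hold at other concentrations.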